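The compounds below may be only part of what the source reports. "The series", "measured", "known", "first", "only" and "open" are said of these compounds alone.

Compound 1 `N[C@H]1CC[C@H](Nc2c(C(=O)NCc3ccc(F)cc3)nc(Br)c3cccnc23)CC1` gives 6000 nM in a functional assay on MDA-MB-435 cells (Homo sapiens) for cytotoxicity, read by MTT assay, with a stated time of 72 h; a lower number here means a stronger inhibitor, a higher number a weaker inhibitor.
Compound 2 `COC(=O)c1nc(Br)c2cccnc2c1N[C@H]1CC[C@H](N)CC1` gives > 20000 nM in this assay.

The value of compound 2 is only a limit of the assay, (the limit of > 20000 nM in this assay, at which 1 of the 2 values shown sits), and not a number. Compound 3 `N[C@H]1CC[C@H](Nc2c(C(=O)Nc3ccccc3)nc(Br)c3cccnc23)CC1` differs from compound 2 by anilino in place of methoxy on a carbonyl carbon. Among the measured compounds shown here, the single measured step at this carbon, an at least 3.3-fold higher number from compound 1 to compound 2 (0.52 log units; beyond the scatter), runs from an amide to the ester. Compound 3 carries an amide again, so a return toward the amide potency is expected, an at least 2.8-fold lower number from compound 2 to compound 3 (0.45 log units; beyond the scatter). Compound 3 is estimated at 7000 nM, with a range from 2500 nM to 20000 nM.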

Compound 3, half-maximal inhibitory concentration: 1000 nM
Compound 3: the middle estimate sits 7.0-fold (0.85 log units) above what was measured; the measured number lies below the stated range.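

In this assay, anilino in place of methoxy on a carbonyl carbon gives an at least 20-fold lower number from compound 2 to compound 3 (1.30 log units; beyond the scatter). The value of compound 2 is a limit and not a number, so this step has no upper end: the limit of > 20000 nM in this assay, at which 1 of the 3 values shown sits. The amides themselves also differ, since phenyl in place of 4-fluorobenzyl on an amide-type nitrogen gives a 6.0-fold lower number from compound 1 to compound 3 (0.78 log units; beyond the scatter), so the group on that nitrogen matters as well as the presence of the amide. As far as these compounds go, what stays open is how a plain benzyl or a 4-fluorophenyl group on that nitrogen would compare, which would separate the fluorine from the chain. From the compounds shown here alone, a carboxylic acid at the carbonyl carbon also stays open.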